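Amine side chains on the shared core: outlook for compound 4

This account rests on a few compounds, and the source may have more. Where it says the series, first, only, none or still open, it means among the compounds named here.

Measured compounds:
compound 1, `CCCCCCCCCCc1ccc(-c2noc(CCCN(C)C)n2)cc1`, 8%
compound 2, `CCCCCCCCCCc1ccc(-c2noc([C@@H]3CCNC3)n2)cc1`, 62%
compound 3, `CCCCCCCCCCc1ccc(-c2noc([C@@H](N)CCN)n2)cc1`, 14%

In an assay on HeLa cells for inhibition of sphingosine-1-phosphate transporter SPNS2 (Mus musculus), read by LC-MS, tested at 2 uM (on this read-out higher numbers stand for more inhibition at the one concentration tested (going by the name of the read-out) and lower numbers for less inhibition), compound 3 gives 14%, the second highest of the three numbers. Its nearest neighbour is compound 1 with 8%, and the two lie within the scatter of each other: a number 6 percentage points higher from compound 1 to compound 3 (within the scatter). Compound 2, with 62%, stands apart; a number 48 percentage points lower from compound 2 to compound 3 (beyond the scatter), and likewise a number 54 percentage points higher from compound 1 to compound 2 (beyond the scatter). Within the data shown here, the only large steps in the set therefore involve compound 2, whose side chain is the one that holds a ring.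

Compound 4 is `CCCCCCCCCCc1ccc(-c2noc([C@H](N)CCCCN)n2)cc1`. Its change from compound 3 is 1,5-diaminopentyl in place of 1,3-diaminopropyl on an aromatic carbon. Among the measured compounds shown here, no measured step alters the length of an open chain while keeping both amines, so none bears directly on this step; the step from compound 1 to compound 3, which swaps one open chain for another, is within the scatter, and the large steps all go through the ring-bearing compound 2. Given that, no step beyond the scatter is expected in this assay: a number 4 percentage points higher from compound 3 to compound 4 (within the scatter) is the estimated change. For compound 4 the expected value in this assay is 18%, with a range from 0% to 45%.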

Compound 4, a percentage reported as inhibition, at one concentration (the size of the read-out at that concentration, not a potency): 50%
For compound 4 the middle estimate is 32 percentage points below the measured one, and the stated range ends below it.
By their numbers in this assay, from the lowest: compounds 1 and 3 (each within the scatter of the next); then compound 4; then compound 2.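

In this assay, among these compounds, the open chain at this position, on an aromatic carbon of the five-membered aromatic ring, turns out to be sensitive to its length with both amines kept: 1,5-diaminopentyl in place of 1,3-diaminopropyl gives a number 36 percentage points higher from compound 3 to compound 4 (beyond the scatter) and is the first large step that does not involve compound 2. A ring in the side chain is therefore not required for a high number, and the same holds against the dimethylamino chain, with a number 42 percentage points higher from compound 1 to compound 4 (beyond the scatter) as the step, while the pyrrolidin-3-yl group still keeps a modest lead, with a number 12 percentage points lower from compound 2 to compound 4 (beyond the scatter) as the step on the way to the open chain. Nothing on hand accounts for the effect of the two added chain carbons.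

Still open, going by these compounds, is the shape of the length effect: a 1,4-diaminobutyl or a 1,6-diaminohexyl group at this position would show whether the number climbs steadily, peaks or falls away. Also open, on these data alone, is the role of the terminal amine, which a 1-aminopentyl chain without it, or a terminal guanidine on the same chain, would separate from chain length.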